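Swapping a Difluoropiperidine for an Acid-Bearing Ether Chain

The source may report more compounds than this note shows. Statements on the series, on what has been measured and on what is new or still open speak of the compounds shown alone.

Compound 1 `COC(=O)C1=C(C)NC(c2nccs2)=NC1(C)c1ccc(C#N)cc1` gives 75 mL/min/kg in an ADME assay on microsomes from liver (Mus musculus) for metabolic stability, read by LC-MS, using NADPH, with stated times of 10 min and 30 min, tested at 1 uM; on this read-out higher numbers stand for fast clearance and lower numbers for slow clearance.
Compound 2 `COC(=O)C1=C(C)NC(c2nccs2)=NC1(C)c1ccc(F)c(F)c1` gives 83 mL/min/kg in this assay.
Compound 3 `COC(=O)C1=C(CN2CCC(F)(F)CC2)NC(c2nccs2)=NC1(C)c1ccc(F)cc1` gives 88 mL/min/kg in this assay.

All three compounds share a core and differ only in the substituents around it. Compound 3 shows the highest of the three numbers, yet its gaps to compound 2 and to compound 1 both lie within the usual scatter, so the three stand together as fast-clearing compounds with no real order among them.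

Compound 4 `COC(=O)C1=C(COC(C(=O)O)C(F)(F)F)NC(c2nccs2)=NC1(C)c1ccc(F)cc1` is the next step. Relative to compound 3, the change is: a group of 9 heavy atoms (3 carbon, 3 oxygen, 3 fluorine; no ring) in place of a group of 8 heavy atoms (5 carbon, 1 nitrogen, 2 fluorine; one six-membered non-aromatic ring with 1 hetero atom), on a saturated chain carbon bound to a double-bonded ring carbon

Among the compounds with values here, the one measured step, a 1.1-fold higher number from compound 1 to compound 2 (0.04 log units; within the scatter), concerns a different place on the core, the aryl ring on the saturated ring carbon, and it moved nothing beyond the scatter. No measured step touches the position changed here, so the data give no direct guide, and the change itself is the largest of those shown.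

The step of a 1.5-fold lower number from compound 3 to compound 4 (0.17 log units; within the scatter) is therefore expected to be a modest lowering that may well stay within the scatter. Compound 4 is estimated at 60 mL/min/kg, with a range from 30 mL/min/kg to 110 mL/min/kg.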

Compound 4, clearance: 24 mL/min/kg
Beside the measured number, compound 4's estimate is 2.5-fold (0.40 log units) above it; measured number outside the range, below it.
By their numbers in this assay, from the lowest: compound 4; then compounds 1, 2 and 3 (each within the scatter of the next).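

At the saturated chain carbon bound to a double-bonded ring carbon, replacing 4,4-difluoropiperidin-1-yl with the acid-bearing ether chain gives a 3.7-fold lower number from compound 3 to compound 4 (0.56 log units; beyond the scatter) in this assay, and this step is a clear lowering of the clearance number. Within the data shown here, the earlier compounds showed only that one change on the aryl ring left the number within the scatter, so they gave no sign that any part of these molecules could shift it. This result shows that the group at this chain position can move the read-out beyond the scatter, at least in the one pair shown here. No evidence is available on why the number falls.

This single step swaps the whole group at once, removing the ring, its nitrogen and its two fluorines while bringing in an ether oxygen, a carboxylic acid and a trifluoromethyl group, so the compounds shown cannot say which of these parts accounts for the lowering. A methyl ester in place of the carboxylic acid, or the same ether chain without the trifluoromethyl group, would begin to separate these parts, and a simple open-chain amine at this position would test the other side of the swap.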